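Trading the Remaining Methoxy for Methyl

The source may hold more compounds than are shown below. What is called first, only, known or untested is meant among the compounds shown, and "the series" means these compounds.

Of the three compounds measured in an ADME assay on microsomes from liver (Homo sapiens) for metabolic stability, with a stated time of 10 min (on this read-out higher numbers stand for a more stable compound and lower numbers for a less stable compound), compound 3 `COc1cc(C)c(Nc2nc(Cl)cn([C@H](C)C3CC3)c2=O)c(C)n1` stands highest at 81%, ahead of compound 1 `COc1ccc(Nc2nc(Cl)cn([C@H](C)C3CC3)c2=O)c(C)n1` at 60% and compound 2 `COc1ccc(Nc2nc(Cl)cn([C@H](C)C3CC3)c2=O)c(OC)n1` at 25%. Compound 4 `Cc1cc(C)c(Nc2nc(Cl)cn([C@H](C)C3CC3)c2=O)c(C)n1` differs from compound 3 by methyl in place of methoxy on an aromatic carbon. The closest evidence is the opposite swap at another place, a number 35 percentage points lower from compound 1 to compound 2 (beyond the scatter), a large step. Adding a methyl in place of hydrogen gave a number 21 percentage points higher from compound 1 to compound 3 (beyond the scatter), a modest step. Both point upward, but compound 3 already reaches 81%, so the expected result is only a number 5 percentage points higher from compound 3 to compound 4 (within the scatter), a small rise not beyond the scatter. Compound 4 is estimated at 86%, with an expected range from 70% to 97%.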

Compound 4, percent of the compound remaining: 76%
Compound 4: the middle estimate sits 10 percentage points above what was measured; low and high end bracket the measured number.
By their numbers in this assay, from the lowest: compound 2; then compound 1; then compounds 4 and 3 (each within the scatter of the next).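

In this assay, methyl in place of methoxy next to the ring nitrogen gave a number 5 percentage points lower from compound 3 to compound 4 (within the scatter), so this exchange does not separate the two compounds at this position. The large effect seen earlier for this pair of groups therefore does not carry over here, and its size depends on where and on which core it is made: the same change on two cores in this assay, a number 35 percentage points lower (beyond the scatter) from compound 1 to compound 2 and a number 5 percentage points higher (within the scatter) from compound 4 to compound 3, 40 percentage points apart, beyond the scatter of two such steps. The compounds shown hold only methoxy and methyl at this position, so how an amine or an ethyl group would fare there remains open.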